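A few compounds are considered here, and "the series" means these few. Any claim that something is new, unique, unknown or untested is made for them only; others in the source may bear on it.

Measured so far:
compound 1 `Nc1nc(-c2ncco2)nc2sc(Cc3ccccc3)cc12` 310 nM
compound 2 `Cc1nc(-c2nc(N)c3cc(Cc4ccccc4)sc3n2)cs1` 263 nM
compound 3 `Nc1nc(-c2ccccc2)nc2sc(Cc3ccccc3)cc12` 151 nM

All three share one core and differ only in the aromatic ring attached to it. In a functional assay on CHO-K1 cells for antagonist activity at adenosine receptor A1 (Homo sapiens), read by a beta-galactosidase reporter and cAMP accumulation, with stated times of 15 min and 6 h (on this read-out higher numbers stand for weaker inhibition and lower numbers for stronger inhibition), compound 3 gives 151 nM, the smallest of the three numbers. Its separation from compound 1 is real: a 2.1-fold lower number from compound 1 to compound 3 (0.31 log units; beyond the scatter). Against compound 2, however, a 1.7-fold lower number from compound 2 to compound 3 (0.24 log units; within the scatter), so these two cannot be told apart, and a 1.2-fold lower number from compound 1 to compound 2 (0.07 log units; within the scatter) likewise shows no clear difference.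

Compound 4 `Nc1nc(-c2cccc(C(F)(F)F)c2)nc2sc(Cc3ccccc3)cc12` keeps the phenyl of compound 3 and carries one addition: trifluoromethyl in place of hydrogen on an aromatic carbon. None of the three measured steps resembles this change. Within the data shown here, they all exchange one whole ring for another, and no compound so far carries any substituent on that ring, so there is no measured step that shows what a trifluoromethyl at this position does. Among the measured compounds shown here, the only guidance is that the ring exchanges themselves moved the number little, with one modest step at most.

For the measured compounds named here, with no step to lean on, compound 4 is expected to stay close to compound 3, the estimated step being a 1.0-fold lower number from compound 3 to compound 4 (0.00 log units; within the scatter). Compound 4 is therefore estimated at 150 nM, with a range from 45 nM to 500 nM to reflect the missing precedent.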

Compound 4, inhibition constant: > 1000 nM
Compound 4: no number, only a limit; the forecaster's own chance of this, stated with the estimate: 3%; middle value at least 6.6-fold (0.82 log units) from the limit.
By their numbers in this assay, from the lowest: compounds 3, 2 and 1 (each within the scatter of the next, the first and the last beyond it). At a limit, above all of these: compound 4.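

Until now, the measured steps only exchanged one whole ring for another, and the largest of them was modest: a 2.1-fold lower number from compound 1 to compound 3 (0.31 log units; beyond the scatter). Compound 4 is the first compound shown with a substituent on that ring, and in this assay this single addition of trifluoromethyl, on an aromatic carbon of the phenyl and meta to a large group, gives a much larger step: an at least 6.6-fold higher number from compound 3 to compound 4 (0.82 log units; beyond the scatter). The phenyl of compound 3 is therefore not free to take any addition at this place, even though swapping the whole ring changed the number so little, and the reading for compound 4 is a limit and not a number, which leaves the step with no upper end: the limit of > 1000 nM in this assay, at which 1 of the 4 values shown sits.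

With a single substituent at a single place, the compounds shown cannot say whether this change follows from trifluoromethyl itself or from any addition at this carbon. A methyl, a methoxy or an amine at the same place, or trifluoromethyl at another carbon of the phenyl, would help to separate these two readings.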